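Sulfonyl aryl swap in a fluorinated sulfone series

The source may hold more compounds than are shown below. What is called first, only, known or untested is meant among the compounds shown, and "the series" means these compounds.

Measured compounds:
compound 1 `COc1cccc(S(=O)(=O)c2cnc3cc(F)ccc3c2-c2cccc(Cl)c2)c1` — 2.97 mL/min
compound 2 `COc1cccc(S(=O)(=O)c2cnc3cc(F)ccc3c2-c2cccc(F)c2)c1` — 3.36 mL/min
compound 3 `O=S(=O)(c1cccc(F)c1)c1cnc2c(F)cccc2c1-c1ccccc1F` — 0.21 mL/min

In an ADME assay on microsomes from liver (Homo sapiens) for metabolic stability, tested at 2.5 uM (a lower number here means slower removal, a higher number faster removal of the compound), compound 1 gives 2.97 mL/min, the second highest of the three numbers. Compound 2 lies nearest to it; compound 3 lies furthest, at a much lower number, beyond the scatter.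

The step to compound 4 `O=S(=O)(c1ccc(F)c(Cl)c1)c1cnc2cc(F)ccc2c1-c1cccc(Cl)c1` changes the aryl group on the sulfonyl sulfur: 3-chloro-4-fluorophenyl in place of 3-methoxyphenyl on a sulfonyl sulfur. Going by the values given here, the only single-point step measured so far is a 1.1-fold higher number from compound 1 to compound 2 (0.05 log units; within the scatter); it concerns a halogen on the other aryl ring and lies within the scatter, so it says little about a swap on the sulfonyl side. Compound 3 also carries a halogenated phenyl on the sulfonyl sulfur and gives 0.21 mL/min, but it differs from compound 1 in several places at once, so no single step can be read from that pair.

Among the compounds with values here, with no direct precedent, a moderately lower number is the expectation for compound 4, which is estimated at 1.5 mL/min with a range of 0.4 mL/min to 5 mL/min; the expected step is a 2.0-fold lower number from compound 1 to compound 4 (0.30 log units; within the scatter).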

Compound 4, intrinsic clearance in a liver preparation (reported as CLH), per the amount of preparation that the assay uses: 0.66 mL/min
Estimate against measurement, compound 4: 2.3-fold (0.36 log units) above, within the range that was stated.
By their numbers in this assay, from the lowest: compound 3; then compound 4; then compounds 1 and 2 (each within the scatter of the next).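

Going by these compounds alone, the sulfonyl aryl group is the first place where a single change moves the number in this assay beyond the scatter: 3-chloro-4-fluorophenyl in place of 3-methoxyphenyl on a sulfonyl sulfur gives a 4.5-fold lower number from compound 1 to compound 4 (0.65 log units; beyond the scatter). Within the data shown here, the one earlier single change, on a halogen of the other aryl ring, gave a 1.1-fold higher number from compound 1 to compound 2 (0.05 log units; within the scatter), so the two positions differ in this pair of steps, though each rests on one step only. Nothing measured here offers an explanation for the step.

From the compounds shown here alone, one pair cannot separate the loss of 3-methoxyphenyl from the gain of 3-chloro-4-fluorophenyl, and the same swap on compound 2 remains open. Also open, going by these compounds, is how an aryl group carrying an amine or a carboxylic acid, or a plain alkyl chain, on the sulfonyl sulfur would read in this assay.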